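Chloro to trifluoromethyl: estimating oral bioavailability

The compounds below may be only part of what the source reports. "The series", "measured", "known", "first", "only" and "open" are said of these compounds alone.

Among the compounds with values here, in an in vivo ADME assay on the whole organism (strain Sprague-Dawley) for pharmacokinetics, with Rattus norvegicus as the target, at a dose of 10 mg/kg by the oral route (a lower number here means that a smaller share of the oral dose reaches the circulation, a higher number that a larger share of the oral dose reaches the circulation), compound 1 (`O=C(CC(c1ccccc1)c1ccccc1)N1CCN(C(c2ccccc2)c2cccc(Cl)c2)CC1`) gives 66% and stands highest of the two numbers so far, while compound 2 (`O=C(NC(c1ccccc1)c1ccccc1)N1CCN(C(c2ccccc2)c2ccccc2)CC1`) gives 22% as the only other number, a gap beyond the scatter. Compound 3 (`O=C(CC(c1ccccc1)c1ccccc1)N1CCN(C(c2ccccc2)c2cccc(C(F)(F)F)c2)CC1`) is still unmeasured. It has trifluoromethyl in place of chloro on an aromatic carbon, meta to a large group. Within the data shown here, no measured pair shows this swap, so no step beyond the scatter is expected in this assay and no direction is clear. The estimated step of a number 6 percentage points lower from compound 1 to compound 3 (within the scatter) is small. Compound 3 is estimated at 60% with an expected range from 35% to 82% as the likely span.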

Compound 3, oral bioavailability: 65%
For compound 3 the middle estimate is 5 percentage points below the measured one, within the range that was stated.
By their numbers in this assay, from the lowest: compound 2; then compounds 3 and 1 (each within the scatter of the next).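

In this assay, the position held by chloro in the 3-chlorophenyl group also accepts trifluoromethyl, with 4 heavy atoms in place of 1, and the step is a number 1 percentage points lower from compound 1 to compound 3 (within the scatter). For this one pair, the larger group leaves the read-out within the usual spread of repeat measurements. No measurement shown here offers an explanation for this result.

As far as these compounds go, whether an amine or a carboxylic acid at this position would give a similar number remains open. This single pair also cannot show whether the same swap would behave alike on a different core.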